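A few compounds are considered here, and "the series" means these few. Any claim that something is new, unique, unknown or untested is made for them only; others in the source may bear on it.

Three compounds that share most of their atoms were tested in a functional assay on HeLa cells (Homo sapiens) for inhibition, read by sulforhodamine B assay; a lower number here means a stronger inhibitor, a higher number a weaker inhibitor. Compound 2 `Cc1ccc(NC2=CC(=O)c3c(nc4n3[C@H]3OC[C@@H](O)[C@H]3OC4)C2=O)cc1` carries a (4-methylphenyl)amino group on its core, and in this assay compound 2 gives 6590 nM. Compound 3 `Cc1ccc(NC2=CC(=O)c3nc4n(c3C2=O)[C@H]2OC[C@@H](O)[C@H]2OC4)cc1` is built from the same atoms, joined differently; how the two cores differ is not broken down here. In this assay compound 3 gives 3860 nM, a value that sits within the usual scatter of that of compound 2, so no order between them can be claimed. Compound 1 `O=C1C(Nc2ccccc2)=CC(=O)c2c1nc1n2[C@H]2OC[C@@H](O)[C@H]2OC1` differs from compound 2 in one place: hydrogen in place of methyl on an aromatic carbon. For compound 1 this assay reports only a limit, > 8000 nM. The step of an at least 1.2-fold higher number from compound 2 to compound 1 (0.08 log units; that floor lies within the scatter) therefore has a floor but no ceiling, because the limit of > 8000 nM in this assay, at which 1 of the 3 values shown sits, is where compound 1 comes to rest.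

Compound 4 `O=C1C=C(Nc2ccccc2)C(=O)c2c1nc1n2[C@H]2OC[C@@H](O)[C@H]2OC1`, not yet measured, differs from compound 3 by the same change, at the same place: hydrogen in place of methyl on an aromatic carbon. What is known of this change comes from a single pair, and that pair gives only a floor, so its real size is open. Compound 4 is expected to give about 7000 nM in this assay, an estimated step of a 1.8-fold higher number from compound 3 to compound 4 (0.26 log units; within the scatter), resting on the floor seen in an at least 1.2-fold higher number from compound 2 to compound 1 (0.08 log units; that floor lies within the scatter). The expected range for compound 4 runs from 3000 nM to 18000 nM. There is also a fair chance that compound 4 is reported only as a limit.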

Compound 4, half-maximal inhibitory concentration: 5620 nM
Compound 4: the middle estimate sits 1.2-fold (0.10 log units) above what was measured; low and high end bracket the measured number.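

In this assay, putting hydrogen in place of the methyl on the aromatic ring, which turns the (4-methylphenyl)amino group into an anilino group, gives a 1.5-fold higher number from compound 3 to compound 4 (0.16 log units; within the scatter), so on this core the change has no effect that can be told apart from ordinary repeat-to-repeat variation. Set beside the same change on the other core, this result gives no firm answer on whether the change carries over with the same size: the same change on two cores in this assay, an at least 1.2-fold higher number (0.08 log units; that floor lies within the scatter) from compound 2 to compound 1 and a 1.5-fold higher number (0.16 log units; within the scatter) from compound 3 to compound 4; the limit leaves it open whether they differ. Compound 1 is reported only as a limit, > 8000 nM, so the step on its core has a floor but no ceiling, and the data show neither that the change transfers unaltered between the two cores nor that it does not.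

The compounds shown hold only hydrogen or methyl at this place on the six-membered aromatic ring, so it remains open how a chlorine, a methoxy group or a longer chain such as ethyl or propyl would read in this assay. Going by these compounds alone, it is also open whether the swap from methyl to hydrogen would stay this small on any core beyond these two, since only one measured pair with two real numbers and one pair with a limit speak to it.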